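A few compounds are considered here, and "the series" means these few. Any claim that something is new, unique, unknown or untested is made for them only; others in the source may bear on it.

Measured so far in a functional assay on PC-3 cells (Homo sapiens) for antiproliferative activity, read by sulforhodamine B assay, with a stated time of 48 h; on this read-out higher numbers stand for weaker inhibition and lower numbers for stronger inhibition
- compound 1 `O=C(CCCCCCN1C(=O)/C(=N\O)c2ccccc21)NO` gives 980 nM
- compound 2 `O=C(CCCCCCN1C(=O)/C(=N\O)c2cc(F)ccc21)NO` gives 2730 nM

Compound 2 holds the higher of the two numbers. Compound 3 `Cc1ccc2c(c1)/C(=N/O)C(=O)N2CCCCCCC(=O)NO` has methyl in place of fluoro on an aromatic carbon and is otherwise unchanged. For the measured compounds named here, the only measured step bearing on this change is a 2.8-fold higher number from compound 1 to compound 2 (0.44 log units; beyond the scatter) for fluoro in place of hydrogen on an aromatic carbon. Going by the values given here, no methyl compound has been measured, so a modest move toward stronger inhibition in this assay is expected only tentatively. The expected step is a 1.7-fold lower number from compound 2 to compound 3 (0.23 log units; within the scatter) in this estimate. Compound 3 is estimated at 1600 nM with an expected range of 650 nM to 4000 nM in this series.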

Compound 3, half-maximal inhibitory concentration: 620 nM
Beside the measured number, compound 3's estimate is 2.6-fold (0.41 log units) above it; measured number below the stated range.
By their numbers in this assay, from the lowest: compounds 3 and 1 (each within the scatter of the next); then compound 2.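

In this assay methyl in place of fluoro gives a 4.4-fold lower number from compound 2 to compound 3 (0.64 log units; beyond the scatter) on this aromatic carbon, while methyl in place of hydrogen gives a 1.6-fold lower number from compound 1 to compound 3 (0.20 log units; within the scatter) on the same carbon. The weaker inhibition seen with fluoro is therefore not shared by methyl, so a group on this carbon does not by itself cost activity. Nothing measured accounts for the difference between the two groups.

From the compounds shown here alone, whether chloro, methoxy or ethyl on this carbon would follow methyl or fluoro stays open. So does the effect of methyl on the other aromatic carbons of the shared core.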